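Cytotoxicity of a dioxolane-bearing triazole-linked quinone derivative

A few compounds are considered here, and "the series" means these few. Any claim that something is new, unique, unknown or untested is made for them only; others in the source may bear on it.

Compound 1 `CC1(C)O[C@@H](CO)[C@H](Cn2cc(Cn3c4c(c5ccccc53)C(=O)c3c[n+]([O-])c5ccccc5c3C4=O)nn2)O1` was tested in a toxicity assay on HEK-293T cells (Homo sapiens) for cytotoxicity, read by MTT assay, with a stated time of 72 h (a higher number here means a weaker inhibitor, a lower number a stronger inhibitor), where compound 1 gives 120 nM. Compound 2 `O=C1c2c[n+]([O-])c3ccccc3c2C(=O)c2[nH]c3ccccc3c21`, which carries the shared core without the triazole-linked dioxolane arm, gives in this assay 890 nM. Compound 1 therefore stands at the lower of the two numbers, and the gap to compound 2 lies beyond the scatter of repeated measurements.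

Compound 3 `CC1(C)OC[C@@H](Cn2cc(Cn3c4c(c5ccccc53)C(=O)c3c[n+]([O-])c5ccccc5c3C4=O)nn2)O1` has not yet been measured in this assay. It differs from compound 1 in one place: 2,2-dimethyl-1,3-dioxolan-4-yl in place of 5-(hydroxymethyl)-2,2-dimethyl-1,3-dioxolan-4-yl on a saturated chain carbon bound to an aromatic nitrogen. The core, the triazole and the dimethyl dioxolane ring are kept; only the hydroxymethyl on the dioxolane is gone.

Among the measured compounds shown here, no step between two measured compounds isolates this change, so the expectation rests on compound 1 alone. The step from compound 1 to compound 3 is expected to be small, a 1.3-fold higher number from compound 1 to compound 3 (0.12 log units; within the scatter), within the scatter or slightly toward a higher number. For compound 3 the expected value in this assay is 160 nM, with a range from 60 nM to 450 nM.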

Compound 3, half-maximal inhibitory concentration: 6020 nM
Compound 3: the middle estimate sits 38-fold (1.58 log units) below what was measured; measured number outside the range, above it.
By their numbers in this assay, from the lowest: compound 1; then compound 2; then compound 3.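

In this assay, taking the hydroxymethyl off the dioxolane ring brings a 50-fold higher number from compound 1 to compound 3 (1.70 log units; beyond the scatter), so this position on the arm is far from silent: the core, the triazole and the dimethyl dioxolane ring are all kept, and this single change carries the whole step. The earlier compounds shown here could not resolve any one part of the arm, whereas this pair ties a large step to the 5-(hydroxymethyl) group on the ring, whose loss also removes one defined stereocentre. Nothing available here explains the step.

The compounds shown leave open whether the hydroxyl oxygen or the extra carbon matters, which a methyl or a methoxymethyl group at this place would help separate. They also leave open how an aminomethyl group, a carboxylic acid or a longer hydroxyethyl chain would read here.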